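Cyclopentyl amide of the shared core: expected channel potency

The source may hold more compounds than are shown below. What is called first, only, known or untested is meant among the compounds shown, and "the series" means these compounds.

Measured compounds:
compound 1 `CCCC(=O)Nc1c(C(O)(C(F)(F)F)C(F)(F)F)ccc2ccccc12`, 131 nM
compound 2 `CC(C)=CC(=O)Nc1c(C(O)(C(F)(F)F)C(F)(F)F)ccc2ccccc12`, 46 nM
compound 3 `C/C=C/C(=O)Nc1c(C(O)(C(F)(F)F)C(F)(F)F)ccc2ccccc12`, 72 nM

In an assay on LtK cells with ATP-sensitive inward rectifier potassium channel 11 (Homo sapiens) as the target (on this read-out higher numbers stand for an effect only at larger amounts of compound and lower numbers for an effect already at smaller amounts), compound 2 gives 46 nM, the lowest of the three numbers, although the gap to compound 3, a 1.6-fold higher number from compound 2 to compound 3 (0.19 log units; within the scatter), lies within the scatter. The clear step is from the propyl amide: a 2.8-fold lower number from compound 1 to compound 2 (0.45 log units; beyond the scatter), whereas a 1.8-fold lower number from compound 1 to compound 3 (0.26 log units; within the scatter) stays within the scatter.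

Compound 4 `O=C(Nc1c(C(O)(C(F)(F)F)C(F)(F)F)ccc2ccccc12)C1CCCC1` differs from compound 2 by cyclopentyl in place of 2-methylprop-1-en-1-yl on a carbonyl carbon. Going by the values given here, the only steps that bear on it are those at the same carbonyl carbon: the unsaturated groups of compound 2 and compound 3 against the saturated propyl of compound 1. Compound 4 carries a saturated group again, so a number nearer to compound 1 is expected, with a modest rise in this assay, a 2.0-fold higher number from compound 2 to compound 4 (0.29 log units; within the scatter). The estimate for compound 4 is 90 nM, with a range from 40 nM to 200 nM.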

Compound 4, half-maximal effective concentration: 495 nM
Compound 4: middle estimate off by 5.5-fold (0.74 log units), on the low side; the whole stated range lies below it.
By their numbers in this assay, from the lowest: compounds 2, 3 and 1 (each within the scatter of the next, the first and the last beyond it); then compound 4.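

In this assay, the cyclopentyl amide stands apart from all three open-chain amides at this carbonyl carbon, with an 11-fold higher number from compound 2 to compound 4 (1.03 log units; beyond the scatter) and a 6.9-fold higher number from compound 3 to compound 4 (0.84 log units; beyond the scatter) and also a 3.8-fold higher number from compound 1 to compound 4 (0.58 log units; beyond the scatter) against the saturated propyl group. Going by these compounds alone, the last of these steps shows that the absence of a double bond does not by itself set the number of compound 4, and the position proves far less tolerant than the earlier compounds suggested, whose widest step was a 2.8-fold lower number from compound 1 to compound 2 (0.45 log units; beyond the scatter). No measurement given here accounts for the step from the open-chain groups to the ring.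

The compounds shown leave open whether a cyclobutyl, cyclohexyl or phenyl group at this carbonyl carbon would give a number like that of compound 4 or like those of the open-chain amides. They also leave open whether a pentyl chain, with as many carbons as cyclopentyl but no ring, would stay near compound 1.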